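Swapping the aniline ring in a shared core

The compounds below may be only part of what the source reports. "The series", "measured", "known", "first", "only" and "open" are said of these compounds alone.

Compound 1 `COc1ccc(Nc2ncc(C(F)(F)F)c(N3Cc4cccc(N(C)S(C)(=O)=O)c4C3)n2)cc1C(F)(F)F` in a functional assay on HepG2 cells (Homo sapiens) for antiproliferative activity, read by spectrophotometry, with a stated time of 2 days; a higher number here means a weaker inhibitor of growth, a lower number a stronger inhibitor of growth: > 30000 nM, a limit of the assay.
Compound 2 `Cc1ccc(Nc2ncc(C(F)(F)F)c(N3Cc4cccc(N(C)S(C)(=O)=O)c4C3)n2)cc1C` in this assay: > 30000 nM, again only a limit.
Compound 3 `COc1cc(Nc2ncc(C(F)(F)F)c(N3Cc4cccc(N(C)S(C)(=O)=O)c4C3)n2)cc(OC)c1` in this assay: 1800 nM.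

Compound 1 thus sits at the limit, and (the limit of > 30000 nM in this assay, at which 2 of the 3 values shown sit). Compound 4 `Cc1ccc(Nc2ncc(C(F)(F)F)c(N3Cc4cccc(N(C)S(C)(=O)=O)c4C3)n2)c(C)c1` differs from compound 1 in one place: 2,4-dimethylphenyl in place of 4-methoxy-3-(trifluoromethyl)phenyl on a nitrogen on an aromatic ring. Within the data shown here, two measured steps bear on this. The step that the two limits leave unreadable from compound 1 to compound 2 cannot be sized. The step of an at least 16-fold lower number from compound 1 to compound 3 (1.22 log units; beyond the scatter) is large, but it introduces a different kind of group. The change to compound 4 resembles the change to compound 2 far more than that to compound 3, so another limit, with no step beyond the scatter, is expected. Compound 4 is estimated at 30000 nM (range 8000 nM to 100000 nM), an expected step of a number no higher from compound 1 to compound 4 (the limit leaves the size open).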

Compound 4, concentration for 50% growth inhibition: 19100 nM
For compound 4 the middle estimate is 1.6-fold (0.20 log units) above the measured one, within the range that was stated.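

With 2,4-dimethylphenyl on this nitrogen, compound 4 gives a real number rather than a limit, but the comparisons with the two limits fix only a floor: an at least 1.5-fold lower number from compound 1 to compound 4 (0.19 log units; that floor lies within the scatter) and an at least 1.5-fold lower number from compound 2 to compound 4 (0.19 log units; that floor lies within the scatter). Changing the dimethylphenyl pattern does not close the gap to 3,5-dimethoxyphenyl, with an 11-fold higher number from compound 3 to compound 4 (1.03 log units; beyond the scatter). Compound 1 and compound 2 remain limits: the limit of > 30000 nM in this assay, at which 2 of the 4 values shown sit.

From the compounds shown here alone, whether the advantage of 3,5-dimethoxyphenyl rests on the methoxy groups themselves or on their arrangement stays open. So does the outcome of placing an amine or a carboxylic acid on this phenyl ring.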